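Aromatic group exchange in the hydroxycarbamoyl series

A few compounds are considered here, and "the series" means these few. Any claim that something is new, unique, unknown or untested is made for them only; others in the source may bear on it.

Among the measured compounds shown here, in a functional assay on A549 cells (Homo sapiens) for inhibition, read by MTT assay, with a stated time of 72 h (a lower number here means a stronger inhibitor, a higher number a weaker inhibitor), compound 1 (`CNC(=O)CCCCCCCn1nc(-c2cnc3[nH]ccc3c2)c2c(N)ncnc21`) gives 51000 nM and compound 2 (`Nc1ncnc2c1c(-c1cnc3[nH]ccc3c1)nn2CCCCCCC(=O)NO`) gives 50000 nM, so compound 2 stands level with the only other measured compound. The next compound to be measured is compound 3 (`Nc1nc2cc(-c3nn(CCCCCCC(=O)NO)c4ncnc(N)c34)ccc2o1`). The change leading to it is a group of 10 heavy atoms (7 carbon, 2 nitrogen, 1 oxygen; one five-membered aromatic ring with 2 hetero atoms, one six-membered aromatic ring of carbon only) in place of a group of 9 heavy atoms (7 carbon, 2 nitrogen; one five-membered aromatic ring with 1 hetero atom, one six-membered aromatic ring with 1 hetero atom), on an aromatic carbon: 2-amino-1,3-benzoxazol-5-yl enters on an aromatic carbon of a five-membered aromatic ring with 2 nitrogen, and the chain with its hydroxycarbamoyl end stays as it is. For the measured compounds named here, the one measured step, a 1.0-fold lower number from compound 1 to compound 2 (0.01 log units; within the scatter), concerns the chain end and not this place. Going by the values given here, it shows only that hydroxycarbamoyl in place of (methylcarbamoyl)methyl left this assay unmoved, and no measured step covers the aromatic group. Any size of step here is therefore a judgement with little support. A moderate step towards a lower number is expected, though a result within the scatter remains possible. The expected step is a 3.3-fold lower number from compound 2 to compound 3 (0.52 log units; beyond the scatter). For compound 3 the estimated value is 15000 nM, with an expected range of 1500 nM to 60000 nM.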

Compound 3, half-maximal inhibitory concentration: 33000 nM
Compound 3: the middle estimate sits 2.2-fold (0.34 log units) below what was measured, and the stated range covers the measured number.
By their numbers in this assay, from the lowest: compounds 3, 2 and 1 (each within the scatter of the next).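

In this assay, the exchange of the aromatic group for 2-amino-1,3-benzoxazol-5-yl, with the hydroxycarbamoyl chain unchanged, gives a 1.5-fold lower number from compound 2 to compound 3 (0.18 log units; within the scatter). This position therefore takes a group with a six-membered aromatic ring of carbon only and a five-membered aromatic ring with 2 hetero atoms, in place of one with a six-membered aromatic ring with 1 hetero atom and a five-membered aromatic ring with 1 hetero atom, and the two groups cannot be told apart in this assay; the exchange at the chain end and this one at the aromatic carbon both lie within the scatter. No supporting measurement is available to account for this result.

Still open, going by these compounds, is whether any group at this aromatic carbon can move the number beyond the scatter, and a plain phenyl or a 3-aminophenyl would give a sharper reading of that question. Also open, on these data alone, is how the 2-amino-1,3-benzoxazol-5-yl group behaves with another chain end, such as a carboxylic acid or a primary amine in place of hydroxycarbamoyl.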